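Benzylsulfonyl in place of difluorobenzylsulfanyl: compound 4

The source may hold more compounds than are shown below. What is called first, only, known or untested is meant among the compounds shown, and "the series" means these compounds.

Measured so far in a functional assay on MCF7 cells (Homo sapiens) for antiproliferative activity, read by MTT assay, with a stated time of 24 h; a lower number here means a stronger inhibitor, a higher number a weaker inhibitor:
- compound 1 `CSc1nnc(COc2cc(C)c3c(C)cc(=O)oc3c2)o1` gives > 100000 nM, which is a limit of the assay and not a number.
- compound 2 `Cc1cc(OCc2nnc(SCc3cccc(F)c3)o2)cc2oc(=O)cc(C)c12` gives 26000 nM.
- compound 3 `Cc1cc(OCc2nnc(SCc3ccc(F)c(F)c3)o2)cc2oc(=O)cc(C)c12` gives 33300 nM.

Compound 3 has the highest of the two numbers read in this assay; its nearest neighbour is compound 2, and the gap between them, a 1.3-fold higher number from compound 2 to compound 3 (0.11 log units; within the scatter), lies within the scatter. The third value, that of compound 1, is only a limit (the limit of > 100000 nM in this assay, at which 1 of the 3 values shown sits).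

Compound 4 `Cc1cc(OCc2nnc(S(=O)(=O)Cc3ccccc3)o2)cc2oc(=O)cc(C)c12` is not yet measured. It differs from compound 3 in one place: benzylsulfonyl in place of (3,4-difluorobenzyl)sulfanyl on an aromatic carbon.

Going by the values given here, two measured steps bear on this change. Bringing the 3,4-difluorophenyl onto the chain carbon gave an at least 3.0-fold lower number from compound 1 to compound 3 (0.47 log units; beyond the scatter), and the single extra fluoro gave a 1.3-fold higher number from compound 2 to compound 3 (0.11 log units; within the scatter), so the fluorines themselves account for little that is visible. Among the compounds with values here, no measured step covers the change from sulfanyl to sulfonyl, so that part is uncovered. The expectation for compound 4 is therefore a step of a 1.2-fold higher number from compound 3 to compound 4 (0.08 log units; within the scatter), roughly none beyond the scatter, with a wide range. Compound 4 is estimated at 40000 nM, between 15000 nM and 100000 nM.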

Compound 4, half-maximal inhibitory concentration: 38600 nM
Compound 4: middle estimate off by 1.0-fold (0.02 log units), on the high side; measured number inside the range.
By their numbers in this assay, from the lowest: compounds 2, 3 and 4 (each within the scatter of the next). At a limit, above all of these: compound 1.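

In this assay, benzylsulfonyl on this aromatic carbon of the five-membered ring gives a 1.2-fold higher number from compound 3 to compound 4 (0.06 log units; within the scatter) against (3,4-difluorobenzyl)sulfanyl and a 1.5-fold higher number from compound 2 to compound 4 (0.17 log units; within the scatter) against (3-fluorobenzyl)sulfanyl, so this change of sulfur link and fluoro pattern together moves the number by no more than the scatter. Against methylsulfanyl, the same group gives an at least 2.5-fold lower number from compound 1 to compound 4 (0.41 log units; beyond the scatter), so the step seen with the two fluorobenzylsulfanyl groups also appears with a benzylsulfonyl group. Compound 1 is held at a limit and not a number: the limit of > 100000 nM in this assay, at which 1 of the 4 values shown sits.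

From the compounds shown here alone, the separate contributions of the sulfonyl link and of the fluoro groups stay open, as compound 4 changes both in one step. Also open, going by these compounds, is how an amine, a carboxylic acid or a longer chain in place of the benzyl would read in this assay.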